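This account rests on a few compounds, and the source may have more. Where it says the series, first, only, none or still open, it means among the compounds named here.

Compound 2 `O=S(=O)(Nc1cccc(CO)c1)c1ccc(-c2ccc(F)cc2)cc1` is measured in a functional assay on J774 cells (Mus musculus) for cytotoxicity, read by resazurin assay, with a stated time of 72 h (a higher number here means a weaker inhibitor, a lower number a stronger inhibitor), at 3500 nM, the highest of the three numbers in hand. Compound 1 `O=S(=O)(Nc1cccc(CO)c1)c1ccc(-c2ccc(Cl)cc2)cc1` carries chloro where compound 2 carries fluoro; in this assay compound 1 gives 2500 nM, and the step of a 1.4-fold higher number from compound 1 to compound 2 (0.15 log units; within the scatter) lies within the scatter. Compound 3 `O=S(=O)(Nc1cccc(CO)c1)c1ccc(-c2ccc(Cl)cc2F)cc1` gives 700 nM, so that the step of a 5.0-fold lower number from compound 2 to compound 3 (0.70 log units; beyond the scatter) is modest but beyond the scatter, as is a 3.6-fold lower number from compound 1 to compound 3 (0.55 log units; beyond the scatter). Compound 4 `O=S(=O)(Nc1cccc(CO)c1)c1ccc(-c2ccc(F)cc2)cc1Cl` differs from compound 2 by chloro in place of hydrogen on an aromatic carbon, on an aromatic carbon of a six-membered aromatic ring of carbon only, ortho to a large group and meta to a 4-fluorophenyl group. Within the data shown here, no measured step places a halogen at that spot. The nearest precedents are the halogen exchange a 1.4-fold higher number from compound 1 to compound 2 (0.15 log units; within the scatter), within the scatter, and the added fluoro of a 3.6-fold lower number from compound 1 to compound 3 (0.55 log units; beyond the scatter), which lowered the number modestly. For compound 4 the expected step is a 1.4-fold lower number from compound 2 to compound 4 (0.15 log units; within the scatter), a lowering that may not clear the scatter. Compound 4 is estimated at 2500 nM in this assay, with a range from 800 nM to 8000 nM.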

Compound 4, half-maximal inhibitory concentration: 1200 nM
Compound 4: the middle estimate sits 2.1-fold (0.32 log units) above what was measured; low and high end bracket the measured number.
By their numbers in this assay, from the lowest: compounds 3 and 4 (each within the scatter of the next); then compounds 1 and 2 (each within the scatter of the next).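

In this assay, chloro in place of hydrogen on an aromatic carbon, ortho to a large group and meta to a 4-fluorophenyl group, gives a 2.9-fold lower number from compound 2 to compound 4 (0.46 log units; beyond the scatter). Among these compounds, the earlier steps changed only halogens within the group that stands here as 4-fluorophenyl, so this is the first sign that the number also responds to a change at this other carbon, and that a single added chloro there moves it beyond the scatter. No evidence is available that accounts for this lowering.

With chloro the only group shown at this carbon, the compounds leave open whether fluoro, a methyl, an amine or a carboxylic acid there would lower the number as well. They also leave open whether the same chloro would give a similar step with the 4-chlorophenyl or 4-chloro-2-fluorophenyl group in place.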